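The compounds below may be only part of what the source reports. "The series", "measured", "known", "first", "only" and "open" are said of these compounds alone.

The study begins with compound 1 `O=c1ccn(CCCCCOc2ccc([N+](=O)[O-])cc2)c(=O)[nH]1` and compound 2 `O=c1ccn(CCCCCOc2ccc(Cl)cc2)c(=O)[nH]1`, for which an ADME assay on HEL cells (Homo sapiens) for cytotoxicity (a lower number here means that less compound is tolerated, a higher number that more compound is tolerated), records compound 1 at "not determined" (no result reported) and compound 2 at "not determined" (no result reported). Within the data shown here, compound 3 `Cc1cccc(OCCCCCn2ccc(=O)[nH]c2=O)c1` is the only member with a reading. In this assay compound 3 gives > 100000 nM, which is a limit of the assay rather than a number. That reading sits at the ceiling noted in the limit of > 100000 nM in this assay, at which 1 of the 3 values shown sits. Compound 4 `Cc1ccc(OCCCCCn2ccc(=O)[nH]c2=O)cc1` differs from compound 3 only by 4-methylphenyl in place of 3-methylphenyl on an oxygen on a saturated carbon. Among the measured compounds shown here, no step between two measured compounds is available, so nothing can be read from a comparison. Since the two have the same atoms joined differently, the expected step in this assay is a number no higher from compound 3 to compound 4 (the limit leaves the size open), none beyond the scatter. Compound 4 is therefore estimated at 100000 nM, within 30000 nM to 300000 nM, most likely again reported only as a limit.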

Compound 4, half-maximal cytotoxic concentration: > 100000 nM
Compound 4 ended at the assay's limit; the forecaster's own chance of this, stated with the estimate: 80%; the middle value lies on the limit itself.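

Compound 3 and compound 4 both stand at a limit of this assay, so no step can be read between them: the limit of > 100000 nM in this assay, at which 2 of the 4 values shown sit.

The compounds shown leave open whether 3-methylphenyl and 4-methylphenyl differ at all in this assay.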